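Moving a methyl on the phenyl ring

The compounds below may be only part of what the source reports. "The series", "measured", "known", "first", "only" and "open" are said of these compounds alone.

Measured compounds:
compound 1 `CC1CCN(c2nc(C(F)(F)F)ccc2CNC(=O)C(c2ccccc2)c2ccc(NS(C)(=O)=O)c(F)c2)CC1` — 1.3 nM
compound 2 `Cc1cccc(C(C(=O)NCc2ccc(C(F)(F)F)nc2N2CCC(C)CC2)c2ccc(NS(C)(=O)=O)c(F)c2)c1` — 0.1 nM

In an assay on CHO cells for antagonist activity at transient receptor potential cation channel subfamily V member 1 (Homo sapiens), read by FLIPR (on this read-out lower numbers stand for stronger inhibition and higher numbers for weaker inhibition), compound 2 stands lowest of the two numbers shown. For the measured compounds named here, its nearest neighbour is compound 1, and the step of a 13-fold lower number from compound 1 to compound 2 (1.11 log units; beyond the scatter) is the only measured step in this set; it comes from a methyl in place of hydrogen on an aromatic carbon.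

Compound 3 `Cc1ccc(C(C(=O)NCc2ccc(C(F)(F)F)nc2N2CCC(C)CC2)c2ccc(NS(C)(=O)=O)c(F)c2)cc1` has the same atoms as compound 2, joined differently: 4-methylphenyl in place of 3-methylphenyl on a saturated chain carbon bound to an aromatic carbon and a carbonyl carbon. Going by the values given here, the one measured step does not match this change. It shows what adding a methyl to the phenyl ring did, not what moving it from one aromatic carbon to another does, so nothing measured bears directly on the step from compound 2 to compound 3. The methyl is kept, so the large gain seen with compound 1 is not expected to be lost entirely, but it may not carry over in full. For compound 3 a modest rise in the number is therefore expected, a 3.0-fold higher number from compound 2 to compound 3 (0.48 log units; beyond the scatter), which may still fall within the scatter. The expected value for compound 3 in this assay is 0.3 nM, with a range from 0.06 nM to 1.5 nM.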

Compound 3, inhibition constant: 1.1 nM
Compound 3: the middle estimate sits 3.7-fold (0.56 log units) below what was measured; measured number inside the range.
By their numbers in this assay, from the lowest: compound 2; then compounds 3 and 1 (each within the scatter of the next).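

In this assay, the place of the methyl on the phenyl ring turns out to matter as much as its presence: with the same atoms joined differently, 4-methylphenyl in place of 3-methylphenyl gives an 11-fold higher number from compound 2 to compound 3 (1.04 log units; beyond the scatter). Adding a methyl to the phenyl ring therefore brings no general gain. Placed as in 3-methylphenyl, it gives a 13-fold lower number from compound 1 to compound 2 (1.11 log units; beyond the scatter), whereas placed as in 4-methylphenyl, it gives a 1.2-fold lower number from compound 1 to compound 3 (0.07 log units; within the scatter), a step within the usual scatter. Nothing available here explains why these two placements of the methyl differ.

Still open, on these data alone, is whether the strong result of compound 2 depends on a methyl specifically, or whether a chlorine atom, a methoxy group or an ethyl group in the same place on the ring would give a similar number. The compounds shown also cannot tell whether the same dependence on placement would hold for those groups, or whether it would hold with a different group in place of the 4-methylpiperidine-type amine of the shared core.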